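This account rests on a few compounds, and the source may have more. Where it says the series, first, only, none or still open, it means among the compounds named here.

The shared core is carried unchanged through the series. Compound 1 `COc1ccc2nc(C)cc(OCC(=O)Nc3ccc4c(c3)CCC4)c2c1` gives 16.9 mL/min/kg in an ADME assay on liver (Homo sapiens) for metabolic stability, read by LC-MS, using S9 fraction, tested at 2 uM; on this read-out higher numbers stand for fast clearance and lower numbers for slow clearance. Compound 2 `COc1ccc2nc(C)cc(OCC(=O)Nc3ccc(C)cc3)c2c1` gives 13.5 mL/min/kg in this assay, and on the two numbers shown it is the lower of the two, with compound 1 nearest; the single measured step, a 1.3-fold lower number from compound 1 to compound 2 (0.10 log units; within the scatter), lies within the scatter, so the two compounds cannot be ordered.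

Compound 3 `COc1ccc2nc(C)cc(OCC(=O)Nc3ccc(C)c(C)c3)c2c1` is not yet measured. Its difference from compound 2 is methyl in place of hydrogen on an aromatic carbon. Within the data shown here, no measured step changes the phenyl in this way; the only step that bears on it is a 1.3-fold lower number from compound 1 to compound 2 (0.10 log units; within the scatter), which exchanged the whole ring group and stayed within the scatter. On that basis a step of a 1.1-fold higher number from compound 2 to compound 3 (0.05 log units; within the scatter) is expected, no larger than the scatter and without a firm direction. For compound 3 the estimated value in this assay is 15 mL/min/kg, with a range from 8 mL/min/kg to 28 mL/min/kg.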

Compound 3, clearance in the liver assay: 16.2 mL/min/kg
For compound 3 the middle estimate is 1.1-fold (0.03 log units) below the measured one, within the range that was stated.
By their numbers in the liver assay, from the lowest: compounds 2, 3 and 1 (each within the scatter of the next).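

Methyl in place of hydrogen on the aromatic carbon ortho to a methyl group and meta to a large group is the only step here that alters the phenyl while keeping it, and in the liver assay it stays within the scatter (a 1.2-fold higher number from compound 2 to compound 3 (0.08 log units; within the scatter)), as does the exchange of the whole ring group for 3,4-dimethylphenyl (a 1.0-fold lower number from compound 1 to compound 3 (0.02 log units; within the scatter)). In a physicochemical assay for permeability, using PAMPA, with a stated time of 5 min, tested at 1 uM (on this read-out lower numbers stand for lower permeability and higher numbers for higher permeability), compound 2 gives 11.4 10^-6 cm/s and compound 3 gives 5.9 10^-6 cm/s, and this step (a 1.9-fold lower number from compound 2 to compound 3 (0.29 log units; within the scatter)) also lies within the scatter, so the added methyl moves neither read-out beyond it. No measurement shown accounts for these results.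

The compounds shown leave open whether an amine or a carboxylic acid at this ring carbon would take either read-out beyond the scatter. They also leave open whether a methoxy group there would do so.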